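Furan-2-yl to furan-3-yl at the assay limit

The source may hold more compounds than are shown below. What is called first, only, known or untested is meant among the compounds shown, and "the series" means these compounds.

Measured so far in a functional assay on HL-60 cells (Homo sapiens) for antiproliferative activity, read by XTT assay, with a stated time of 72 h (a higher number here means a weaker inhibitor, a lower number a stronger inhibitor), as follows:

- compound 1 `Cc1nc(N)c2c(-c3ccccc3)cn([C@@H]3O[C@H](CO)[C@@H](O)[C@H]3O)c2n1` gives > 20000 nM as a limit
- compound 2 `Nc1nc2c(c(-c3ccco3)cn2[C@@H]2O[C@H](CO)[C@@H](O)[C@H]2O)c(=O)[nH]1` gives > 20000 nM as a limit

Compound 2 carries no number in this assay and stands only at the limit of > 20000 nM in this assay, at which 2 of the 2 values shown sit, without a closer reading. The next compound, compound 3 `Nc1nc2c(c(-c3ccoc3)cn2[C@@H]2O[C@H](CO)[C@@H](O)[C@H]2O)c(=O)[nH]1`, has furan-3-yl in place of furan-2-yl on an aromatic carbon and keeps the same atoms, joined differently. Within the data shown here, no measured step shows what such a change does, so any expectation rests on compound 2 at the limit of > 20000 nM in this assay, at which 2 of the 2 values shown sit, and on the small size of the change. No step beyond the usual scatter is expected in this assay and no direction is favoured, and the estimated size is a number no higher from compound 2 to compound 3 (the limit leaves the size open) with a limit again the likeliest reading. The expected value for compound 3 is 20000 nM (estimated range 6000 nM to 40000 nM).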

Compound 3, half-maximal inhibitory concentration: > 15000 nM
Compound 3: a limit, no number; the forecaster's own chance of this, stated with the estimate: 75%; the middle value does not contradict the limit.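

Compound 2 and compound 3 both stand only as limits in this assay, so no step can be read for furan-3-yl in place of furan-2-yl. The compounds shown leave open how these two groups compare in this assay, and whether either gives a measurable half-maximal inhibitory concentration.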